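The compounds below may be only part of what the source reports. "The series", "measured", "known", "first", "only" and "open" are said of these compounds alone.

Three compounds sharing one core were run in an ADME assay on MRC5 cells (Homo sapiens) for cytotoxicity, read by MTT assay, with a stated time of 6 days; a higher number here means a weaker inhibitor, a lower number a stronger inhibitor. In this assay compound 1 `O=C1C=C[C@@H](OCc2ccccc2)[C@@H]([C@@H](COC(=O)/C=C/c2ccccc2)OCc2ccccc2)O1` gives only a limit, > 100000 nM. Compound 2 `COc1ccc(/C=C/C(=O)OC[C@@H](OCc2ccccc2)[C@H]2OC(=O)C=C[C@H]2OCc2ccccc2)cc1`, which carries a methoxy in place of hydrogen on an aromatic carbon, likewise gives only a limit in this assay, > 100000 nM. Compound 3 `CC(=O)OC[C@@H](OCc1ccccc1)[C@H]1OC(=O)C=C[C@H]1OCc1ccccc1`, with a methyl in place of the 2-phenylethenyl on the carbonyl carbon, also stands at a limit in this assay, > 100000 nM. Within the data shown here, because all three values sit at one and the same limit (the limit of > 100000 nM in this assay, at which 3 of the 3 values shown sit), no step between them can be read: a step that the two limits leave unreadable from compound 1 to compound 2, a step that the two limits leave unreadable from compound 1 to compound 3 and a step that the two limits leave unreadable from compound 2 to compound 3 are each of unknown size. On the numbers shown, compound 3 therefore stands exactly where its two neighbours stand, at the limit, and nothing more can be said of it.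

Compound 4 `O=C1C=C[C@@H](OCc2ccccc2)[C@@H]([C@@H](CO)OCc2ccccc2)O1` is the next change: hydrogen in place of acetyl on an oxygen on a saturated carbon. Among the measured compounds shown here, none of the measured steps bears on this change directly, and the three that exist give no readable size in any direction. These data offer no ground for expecting a change beyond the scatter, so a number no higher from compound 3 to compound 4 (the limit leaves the size open) is expected to be no step beyond the scatter. Compound 4 is therefore estimated at 100000 nM in this assay, within 50000 nM to 300000 nM, and is most likely to be reported again only as a limit.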

Compound 4, half-maximal inhibitory concentration: > 100000 nM
Compound 4: no number, only a limit (the forecaster's own chance of this, stated with the estimate: 80%); the middle value sits exactly at the limit.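

Compound 4 joins compound 1, compound 2 and compound 3 at the same limit, so no step among these four compounds can be read: the limit of > 100000 nM in this assay, at which 4 of the 4 values shown sit.

The compounds shown leave open whether any of the four has a measurable half-maximal inhibitory concentration in this assay and whether changing the group on that oxygen alters it.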